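Amide-linked series: benzylamide to anilide step in lipophilicity

A few compounds are considered here, and "the series" means these few. Any claim that something is new, unique, unknown or untested is made for them only; others in the source may bear on it.

Measured so far:
compound 1 `Cc1cc(C)cc(NC(=O)COc2cc(C)nc3ccc(F)cc23)c1`: 5.79
compound 2 `COc1ccc2nc(C)c(NC(=O)C(=O)Nc3cc(C)cc(C)c3)c(O)c2c1`: 3.76
compound 3 `COc1ccc2nc(C)cc(OCC(=O)NCc3cc(C)cc(C)c3)c2c1`: 5.25

All three were read in a physicochemical assay for lipophilicity, read by HPLC, in phosphate buffer, measured as chromatographic lipophilicity, at pH 7.4; a higher number here means a more lipophilic compound, a lower number a more polar compound. Compound 3 holds the second-highest value of the three: in this assay compound 1 gives 5.79, a number above compound 3 by more than the scatter, while compound 2 gives 3.76, a number well below compound 3 and again beyond the scatter. Going by the values given here, compounds 1 and 2 each differ from compound 3 in more than one place, so no single step can be isolated between them.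

Compound 4 `COc1ccc2nc(C)cc(OCC(=O)Nc3cccc(C)c3)c2c1` is not yet measured. It differs from compound 3 in one place: 3-methylphenyl in place of 3,5-dimethylbenzyl on an amide-type nitrogen. The group that enters is smaller than the one that leaves, and the ring is now attached directly to the amide-type nitrogen instead of through the benzyl linkage. Among the compounds with values here, no measured pair in the set isolates this change, so the expectation rests on the general size of the groups. A small decrease is expected, with the step from compound 3 to compound 4 estimated at a number 0.20 log units lower from compound 3 to compound 4 (within the scatter), which may sit within the scatter. For compound 4 in this assay the estimate is 5.05, with a range from 4.55 to 5.55.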

Compound 4, distribution coefficient: 4.83
For compound 4 the middle estimate is 0.22 log units above the measured one; the measured number falls inside the stated range.
By their numbers in this assay, from the lowest: compound 2; then compound 4; then compound 3; then compound 1.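

In this assay the exchange of 3,5-dimethylbenzyl for 3-methylphenyl on the amide-type nitrogen gives the first readable step in the series, a number 0.42 log units lower from compound 3 to compound 4 (beyond the scatter) and so this position is shown to respond to the group it carries. Compounds 1 and 2 could not show this, as each differs from compound 3 in more than one place. Nothing measured accounts for the size of the step.

The step combines two structural differences, the benzyl linkage and the second ring methyl, going from 9 to 7 heavy atoms, and the compounds shown do not separate them. A 3-methylbenzyl group on the same amide-type nitrogen would divide the step, while a longer chain such as 2-phenylethyl would test whether the trend extends further.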